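Sulfonyl substituent variation in the aryl-alkyne acid series

The source may hold more compounds than are shown below. What is called first, only, known or untested is meant among the compounds shown, and "the series" means these compounds.

Compound 3 `CCN(CC)S(=O)(=O)c1ccc(C)c(C#Cc2cc(Cl)ccc2OCC(=O)O)c1` sits at the low end of the measured numbers, giving 3.4 nM in an assay on CHO cells for displacement of a labelled ligand from prostaglandin D2 receptor 2 (Homo sapiens), read by scintillation counting; a higher number here means a weaker inhibitor, a lower number a stronger inhibitor. Compound 2 `COCCNS(=O)(=O)c1ccc(C)c(C#Cc2cc(Cl)ccc2OCC(=O)O)c1` gives 3.6 nM, a value within the scatter of compound 3, while compound 1 `Cc1ccc(S(=O)(=O)CCO)cc1C#Cc1cc(Cl)ccc1OCC(=O)O` gives 19 nM. The steps of a 5.6-fold lower number from compound 1 to compound 3 (0.75 log units; beyond the scatter) and a 5.3-fold lower number from compound 1 to compound 2 (0.72 log units; beyond the scatter) show that replacing the 2-hydroxyethyl group on the sulfonyl sulfur lowers the number modestly, whereas a 1.1-fold lower number from compound 2 to compound 3 (0.02 log units; within the scatter) is flat. Compound 4 `CCS(=O)(=O)c1ccc(C)c(C#Cc2cc(Cl)ccc2OCC(=O)O)c1` carries ethyl in place of diethylamino on a sulfonyl sulfur. For the measured compounds named here, no measured step covers this exchange directly; compound 1 is the only analogue with carbon on the sulfonyl sulfur and it reads the highest. A modest rise is therefore expected, a 2.4-fold higher number from compound 3 to compound 4 (0.37 log units; beyond the scatter). Compound 4 is estimated at 8 nM, within 3 nM to 22 nM.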

Compound 4, inhibition constant: 8.6 nM
Compound 4: the middle estimate sits 1.1-fold (0.03 log units) below what was measured, and the stated range covers the measured number.
By their numbers in this assay, from the lowest: compounds 3 and 2 (each within the scatter of the next); then compound 4; then compound 1.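

With only carbon on the sulfonyl sulfur and no hydroxy, compound 4 separates two changes that compound 1 had left joined. Removing the hydroxy alone gives a 2.2-fold lower number from compound 1 to compound 4 (0.34 log units; beyond the scatter), while the amino groups still read lower, with a 2.5-fold higher number from compound 3 to compound 4 (0.40 log units; beyond the scatter) and a 2.4-fold higher number from compound 2 to compound 4 (0.38 log units; beyond the scatter), so both changes contribute to the earlier gaps from compound 1. No measured evidence explains either step.

Going by these compounds, a longer alkyl chain or an unsubstituted amino group on the sulfonyl sulfur remains open. So does whether the nitrogen itself or the carbons attached to it carry the difference.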